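Replacing the carbamate of compound 2 with a fluorinated oxadiazole

A few compounds are considered here, and "the series" means these few. Any claim that something is new, unique, unknown or untested is made for them only; others in the source may bear on it.

Compound 1 `Cc1nc(S(C)(=O)=O)ccc1Oc1ncnc(OC2CCN(C(=O)OC(C)(C)C#N)CC2)c1F`: 92.9 nM
Compound 2 `Cc1nc(S(C)(=O)=O)ccc1Oc1ncnc(OC2CCN(C(=O)O[C@H](C)C(F)(F)F)CC2)c1F`: 9.2 nM

In a functional assay on isolated protein for inhibition of Glucose-dependent insulinotropic receptor (Homo sapiens), read by HTRF and cAMP accumulation (a lower number here means that less compound is needed, a higher number that more compound is needed for the effect), compound 2 gives the lowest of the two numbers; its nearest neighbour, compound 1, gives 92.9 nM, and the step of a 10-fold lower number from compound 1 to compound 2 (1.00 log units; beyond the scatter) is beyond the scatter. Compound 3 `Cc1nc(S(C)(=O)=O)ccc1Oc1ncnc(OC2CCN(C(=O)c3nc(C(C)(C)F)no3)CC2)c1F` carries a group of 9 heavy atoms (5 carbon, 2 nitrogen, 1 oxygen, 1 fluorine; one five-membered aromatic ring with 3 hetero atoms) in place of a group of 7 heavy atoms (3 carbon, 1 oxygen, 3 fluorine; no ring), on a carbonyl carbon. Among the measured compounds shown here, the single known step changed only a group on that oxygen, whereas here the oxygen itself leaves, so no measured step speaks directly to this change, and the direction is open. Compound 3 is expected to stay close to compound 2, with a 1.3-fold higher number from compound 2 to compound 3 (0.12 log units; within the scatter) as the estimated step, giving 12 nM within 3 nM to 50 nM.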

Compound 3, half-maximal effective concentration: 43.4 nM
Compound 3: the middle estimate sits 3.6-fold (0.56 log units) below what was measured; low and high end bracket the measured number.
By their numbers in this assay, from the lowest: compound 2; then compound 3; then compound 1.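

In this assay, the oxygen on this carbonyl carbon is not needed for activity in the nanomolar range: with a five-membered aromatic ring in its place, compound 3 falls between the two carbamates (a 4.7-fold higher number from compound 2 to compound 3 (0.67 log units; beyond the scatter); a 2.1-fold lower number from compound 1 to compound 3 (0.33 log units; beyond the scatter)). The swap therefore costs activity against the better carbamate but still improves on the weaker one. No measurement shown explains this difference. The compounds shown leave open whether the fluorine on the oxadiazole matters, and whether a methyl group or an amine on that ring would bring the number closer to that of compound 2.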